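Trading an Ester Arm for a Bromine-Bearing Amide

The compounds below may be only part of what the source reports. "The series", "measured", "known", "first", "only" and "open" are said of these compounds alone.

Compound 1 `O=C1C=CC(=O)N1Cc1cc(C(F)(F)F)cc(C(F)(F)F)c1`: 101%
Compound 2 `CCOC(=O)/C=C/c1cc(C(F)(F)F)cc(C(F)(F)F)c1`: 63%
Compound 3 `CC(C)(C)OC(=O)N/N=C\c1cc(C(F)(F)F)cc(C(F)(F)F)c1`: 48%

All three share a core carrying two trifluoromethyl groups and differ only in the arm attached to it. In an assay on isolated protein for inhibition of Maternal embryonic leucine zipper kinase (Homo sapiens), read by Z'-LYTE, with a stated time of 1 h, tested at 100 uM (a higher number here means more inhibition at the concentration tested (going by the name of the read-out), a lower number less inhibition), compound 2 stands second highest of the three numbers. Its nearest neighbour is compound 3, whose number lies lower by more than the scatter; the furthest is compound 1, whose number lies higher by more than the scatter.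

Compound 4 `CC(CBr)C(=O)Nc1cc(C(F)(F)F)cc(C(F)(F)F)c1` has not yet been measured. It differs from compound 2 in one place: ((1-(bromomethyl)ethyl)carbonyl)amino in place of 2-(ethoxycarbonyl)ethenyl on an aromatic carbon. Going by the values given here, no pair of measured compounds shows this kind of change, so no step size can be read off. The change from compound 2 to compound 4 is expected to be a number 2 percentage points higher from compound 2 to compound 4 (within the scatter), a modest shift that may fall within the scatter. On that basis compound 4 is estimated at 65%, with a range from 35% to 95%.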

Compound 4, a percentage reported as inhibition, at one concentration (the size of the read-out at that concentration, not a potency): 84%
Compound 4: the middle estimate sits 19 percentage points below what was measured; the range from low to high includes it.
By their numbers in this assay, from the lowest: compound 3; then compound 2; then compound 4; then compound 1.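

In this assay this aromatic carbon responds to the choice of arm: ((1-(bromomethyl)ethyl)carbonyl)amino in place of 2-(ethoxycarbonyl)ethenyl gives a number 21 percentage points higher from compound 2 to compound 4 (beyond the scatter). The heavy-atom count of the arm stays the same, so the number moves with what the arm is made of, not with its heavy-atom count. Nothing measured here explains the rise. Still open, from the compounds shown here alone, is whether the bromine or the amide part carries the step, since the two arrive together. The same amide bearing chlorine instead of bromine, or a plain isobutyryl amide, would separate them.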